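Swapping Bromo for Fluoro on an Inactive Sulfonyl

The compounds below may be only part of what the source reports. "The series", "measured", "known", "first", "only" and "open" are said of these compounds alone.

Three compounds share one core and differ only at a sulfur-linked arm. Compound 1 `CC(O)(CSc1ccc(Br)cc1)c1nc(-c2ccc([N+](=O)[O-])c(C(F)(F)F)c2)no1` gives 1600 nM in a functional assay on DU-145 cells (Homo sapiens) for cytotoxicity, read by MTT assay; a higher number here means a weaker inhibitor, a lower number a stronger inhibitor. Compound 2 `CC(O)(CSc1ccc(Cl)cc1)c1nc(-c2ccc([N+](=O)[O-])c(C(F)(F)F)c2)no1` gives 1300 nM in this assay. Compound 3 `CC(O)(CS(=O)(=O)c1ccc(Br)cc1)c1nc(-c2ccc([N+](=O)[O-])c(C(F)(F)F)c2)no1` reaches only a limit of the assay, > 100000 nM, so no exact number is known for it; it sits at the limit of > 100000 nM in this assay, at which 1 of the 3 values shown sits. Exchanging one halogen for another gave a 1.2-fold lower number from compound 1 to compound 2 (0.09 log units; within the scatter), whereas turning the sulfanyl into a sulfonyl gave an at least 62-fold higher number from compound 1 to compound 3 (1.79 log units; beyond the scatter) and an at least 76-fold higher number from compound 2 to compound 3 (1.88 log units; beyond the scatter).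

Compound 4 `CC(O)(CS(=O)(=O)c1ccc(F)cc1)c1nc(-c2ccc([N+](=O)[O-])c(C(F)(F)F)c2)no1` differs from compound 3 by fluoro in place of bromo on an aromatic carbon. The halogen swap already measured stayed within the scatter, while the sulfonyl, which compound 4 keeps, carried the large loss. Only a change within the scatter is therefore expected from a step that the limit leaves unreadable from compound 3 to compound 4. Compound 4 is expected to give about 150000 nM, plausibly between 30000 nM and 1000000 nM, and most likely to return only a limit again.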

Compound 4, half-maximal inhibitory concentration: > 100000 nM
Compound 4 gave a limit, no number (the forecaster's own chance of this, stated with the estimate: 85%); the middle value lies beyond the limit too.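

In this assay compound 4 returns > 100000 nM, which is a limit of the assay and not a number. With fluoro on the ring the sulfonyl arm still sits at that limit, and the sulfanyl compounds stand clearly apart, with an at least 76-fold higher number from compound 2 to compound 4 (1.88 log units; beyond the scatter) and an at least 62-fold higher number from compound 1 to compound 4 (1.79 log units; beyond the scatter), so the large loss seen with compound 3 is not tied to its bromo. The step between the two sulfonyl compounds cannot be read, so fluoro and bromo cannot be ranked on this arm: the limit of > 100000 nM in this assay, at which 2 of the 4 values shown sit.

From the compounds shown here alone, whether a sulfinyl arm, with a single oxygen on the sulfur, would sit nearer the sulfanyl or the sulfonyl compounds remains open. So does whether an amine on the ring of the sulfonyl arm would bring a measurable number.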